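A few compounds are considered here, and "the series" means these few. Any claim that something is new, unique, unknown or untested is made for them only; others in the source may bear on it.

Compound 1 `O=c1[nH]c(=O)n([C@@H]2O[C@H](COP(=O)(O)OP(=O)(O)OP(=O)(O)O)[C@@H](O)[C@H]2O)cc1Br` is a nucleotide-like molecule tested in an in vitro functional assay on 1321-N1 cells for agonist activity at P2Y purinoceptor 2 (Homo sapiens) (a higher number here means that more compound is needed for the effect, a lower number that less compound is needed), where compound 1 gives 347 nM. Compound 2 `O=c1[nH]c(=O)n([C@@H]2O[C@H](COP(=O)(O)OP(=O)(O)O)[C@@H](O)[C@H]2O)cc1Br` keeps the same core and differs in one place: a hydrogen atom in place of a group of 4 heavy atoms (3 oxygen, 1 phosphorus; no ring), on an oxygen. In this assay compound 2 gives 3670 nM, so the step is an 11-fold higher number from compound 1 to compound 2 (1.02 log units; beyond the scatter). Compound 3 `Cc1cc(=O)n([C@@H]2O[C@H](COP(=O)(O)OP(=O)(O)O)[C@@H](O)[C@H]2O)c(=O)[nH]1` is built on a different core; how the two cores differ is not broken down here. For compound 3 this assay reports only a limit, > 1000 nM, not a number. That limit is one of the values described by the limit of > 1000 nM in this assay, at which 1 of the 3 values shown sits. Compound 4 `Cc1cc(=O)n([C@@H]2O[C@H](COP(=O)(O)O)[C@@H](O)[C@H]2O)c(=O)[nH]1` is compound 3 carrying the same change that turned compound 1 into compound 2: a hydrogen atom in place of a group of 4 heavy atoms (3 oxygen, 1 phosphorus; no ring), on an oxygen. The step expected here is a step that the limit leaves unreadable from compound 3 to compound 4, resting on compound 2, whose step an 11-fold higher number from compound 1 to compound 2 (1.02 log units; beyond the scatter) came from the identical change, and on compound 3 already standing at the limit (the limit of > 1000 nM in this assay, at which 1 of the 3 values shown sits). Compound 4 is therefore expected to give around 30000 nM, most likely reported again only as a limit, with a likely range from 8000 nM to 150000 nM.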

Compound 4, half-maximal effective concentration: > 100000 nM
Compound 4 ended at the assay's limit; the forecaster's own chance of this, stated with the estimate: 80%; middle value at least 3.3-fold (0.52 log units) from the limit.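

In this assay compound 3 gives > 1000 nM, which is a limit and not a number. Compound 4 gives > 100000 nM, which is also a limit, so the step between compound 3 and compound 4 cannot be read. The compounds shown leave open whether the same change has an effect on the core of compound 3 of similar size to an 11-fold higher number from compound 1 to compound 2 (1.02 log units; beyond the scatter).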